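The source may report more compounds than this note shows. Statements on the series, on what has been measured and on what is new or still open speak of the compounds shown alone.

Of the compounds shown here, two share a core and have been measured. Compound 1 `COc1ccc(-c2nc(SC)n(C)c(=O)c2C#N)cc1` gives, in a functional assay, with a stated time of 20 min (a higher number here means a weaker inhibitor, a lower number a stronger inhibitor), 58 ug/mL. Compound 2 `COc1ccc(-c2nc(NN)n(C)c(=O)c2C#N)cc1`, in this assay, gives 41 ug/mL. Among the compounds with values here, the only measured step, a 1.4-fold lower number from compound 1 to compound 2 (0.15 log units; within the scatter), changes a group on the core and not the ring that is altered next. Compound 2 thus stands at a number that compound 1 matches within the scatter, so neither can be called the stronger of the two.

Compound 3 `CN(C)c1ccc(-c2nc(NN)n(C)c(=O)c2C#N)cc1` is not yet measured. It differs from compound 2 by dimethylamino in place of methoxy on an aromatic carbon. Within the data shown here, no measured step touches this ring, so nothing in the data says whether the change should move the number, and the fair expectation is a step of no more than the scatter. The step from compound 2 to compound 3 is therefore estimated as no change at the digits printed from compound 2 to compound 3 (within the scatter). Compound 3 is expected to give 41 ug/mL, within a range from 18 ug/mL to 95 ug/mL.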

Compound 3, half-maximal inhibitory concentration: 81 ug/mL
Compound 3: middle estimate off by 2.0-fold (0.30 log units), on the low side, within the range that was stated.
By their numbers in this assay, from the lowest: compounds 2, 1 and 3 (each within the scatter of the next).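

Within the data shown here, this is the first reading on the ring that carries the methoxy of compound 2. Putting dimethylamino (3 heavy atoms) in place of methoxy (2 heavy atoms), para to a large group, gives a 2.0-fold higher number from compound 2 to compound 3 (0.30 log units; within the scatter) in this assay, so the numbers of these two compounds cannot be told apart and this place tolerates the exchange at this level of resolution. Nothing measured here offers a reason for the size of this step.

Among these compounds, with only two groups read at this place, it remains open how a carboxylic acid, a primary amine or a longer chain such as butoxy would behave there. From the compounds shown here alone, it is also open whether dimethylamino gives a similar step when methylsulfanyl replaces aminoamino on the shared core.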